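Chloro Removal on the Benzamide Aryl of Compound 2

This account rests on a few compounds, and the source may have more. Where it says the series, first, only, none or still open, it means among the compounds named here.

Of the compounds shown here, two have been measured in a functional assay on MDA-MB-468 cells (Homo sapiens) for inhibition, read by sulforhodamine B assay, with a stated time of 48 h; a lower number here means a stronger inhibitor of growth, a higher number a weaker inhibitor of growth. Compound 1 `O=C(Nc1cccc(-n2cc(-c3ccncc3)c(-c3ccc(Cl)c(O)c3)n2)c1)Nc1ccc(Cl)c(Cl)c1` gives 729 nM in this assay. Compound 2 `COc1cc(-c2nn(-c3cccc(NC(=O)c4ccc(Cl)c(C(F)(F)F)c4)c3)cc2-c2ccncc2)ccc1Cl` gives 3690 nM in this assay, the higher of the two numbers; the gap between compound 1 and compound 2 lies beyond the usual scatter, so compound 2 is the weaker growth inhibitor of the pair. Going by the values given here, no step between measured compounds that differ in a single place exists, so there is no measured precedent for the change that follows.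

Compound 3 `COc1cc(-c2nn(-c3cccc(NC(=O)c4cccc(C(F)(F)F)c4)c3)cc2-c2ccncc2)ccc1Cl` is not yet measured in this assay. It differs from compound 2 in one place: hydrogen in place of chloro on an aromatic carbon. The chloro that leaves sits ortho to a trifluoromethyl group and para to a large group, and the difference read one bond further out is 4-chloro-3-(trifluoromethyl)phenyl to 3-(trifluoromethyl)phenyl.

With no measured step of this kind in the series, the expectation rests on the value of compound 2 alone. For compound 3 the expected step in this assay, a 1.5-fold higher number from compound 2 to compound 3 (0.17 log units; within the scatter), is a modest weakening, of a size not clearly beyond the scatter. Compound 3 is estimated at 5500 nM in this assay, with a range of 2200 nM to 14000 nM.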

Compound 3, concentration for 50% growth inhibition: 1320 nM
The estimate for compound 3 lay 4.2-fold (0.62 log units) above the measured number, outside the stated range (below it).
By their numbers in this assay, from the lowest: compounds 1 and 3 (each within the scatter of the next); then compound 2.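

In this assay, going by these compounds alone, taking the chloro off the benzamide aryl gives a 2.8-fold lower number from compound 2 to compound 3 (0.45 log units; beyond the scatter), the only single-place step so far. At this aromatic carbon, ortho to a trifluoromethyl group and para to a large group, growth inhibition therefore does not depend on the chloro, and hydrogen gives the lower number in this background. The step is modest and rests on a single pair, so it describes 3-(trifluoromethyl)phenyl against 4-chloro-3-(trifluoromethyl)phenyl on this one core, and nothing at hand explains why the number moves in this direction.

The compounds shown leave open whether the same change would read the same way with the trifluoromethyl group replaced, or on the urea-linked aryl of compound 1, which also carries a chloro. Going by these compounds, it is also open how this carbon would tolerate a group other than hydrogen or chloro, such as a nitrile, an amine or a carboxylic acid, and whether any of these would move the number further in either direction.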